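This account rests on a few compounds, and the source may have more. Where it says the series, first, only, none or still open, it means among the compounds named here.

Working notes on the series. The three measured compounds share one core and differ only in the aryl group on the carbonyl carbon: compound 1 `COc1ccc(-c2cc3ccccc3nc2/C=C/C(=O)c2ccc(O)cc2)cc1`, compound 2 `COc1ccc(-c2cc3ccccc3nc2/C=C/C(=O)c2ccc(OC)cc2OC)cc1` and compound 3 `COc1ccc(-c2cc3ccccc3nc2/C=C/C(=O)c2ccc(N)cc2)cc1`. In a functional assay on NCI-H1299 cells (Homo sapiens) for antiproliferative activity, read by XTT assay, with a stated time of 72 h (a higher number here means a weaker inhibitor, a lower number a stronger inhibitor), compound 1 gives 8970 nM, compound 2 gives 3770 nM and compound 3 gives 6510 nM. Compound 3 thus stands second highest of the three numbers, nearer to compound 1 than to compound 2. The swaps at this position have moved the numbers only modestly: a 2.4-fold lower number from compound 1 to compound 2 (0.38 log units; beyond the scatter), a 1.7-fold higher number from compound 2 to compound 3 (0.24 log units; within the scatter), while a 1.4-fold lower number from compound 1 to compound 3 (0.14 log units; within the scatter).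

Compound 4 `COc1ccc(-c2cc3ccccc3nc2/C=C/C(=O)c2ccco2)cc1` is not yet measured. It changes the same position: furan-2-yl in place of 4-aminophenyl on a carbonyl carbon. All three measured steps bear on this change, since each also varies the group on the carbonyl carbon, and none exceeded a modest size. A step of similar scale is therefore expected in this assay, with no confident direction; the estimate leans to a number close to that of compound 3, so that a 1.2-fold higher number from compound 3 to compound 4 (0.06 log units; within the scatter) is expected. For compound 4 the expected value is 7500 nM, with a range from 2500 nM to 22000 nM.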

Compound 4, half-maximal inhibitory concentration: 730 nM
The estimate for compound 4 lay 10-fold (1.01 log units) above the measured number, outside the stated range (below it).
By their numbers in this assay, from the lowest: compound 4; then compounds 2, 3 and 1 (each within the scatter of the next, the first and the last beyond it).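

In this assay, the group on the carbonyl carbon can move the number much further than the earlier aryl swaps showed: furan-2-yl gives an 8.9-fold lower number from compound 3 to compound 4 (0.95 log units; beyond the scatter), a 5.2-fold lower number from compound 2 to compound 4 (0.71 log units; beyond the scatter) and a 12-fold lower number from compound 1 to compound 4 (1.09 log units; beyond the scatter). Going by these compounds alone, compound 4 is the only compound here whose steps to all the others lie beyond the scatter, and it is also the only one with a five-membered aromatic ring on the carbonyl carbon rather than a six-membered aromatic ring of carbon only. No measurement at hand accounts for this difference.

The compounds shown do not separate the ring oxygen from the ring size or from the attachment point on the ring. Thiophen-2-yl, furan-3-yl and pyridin-2-yl groups on the same carbonyl carbon would address these questions.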